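A few compounds are considered here, and "the series" means these few. Any claim that something is new, unique, unknown or untested is made for them only; others in the source may bear on it.

Compound 1 `O=C(C1CCCN(Cc2ccccc2)C1)N1CCN(c2ccccc2Cl)CC1` and compound 2 `O=C(C1CCCN(Cc2ccccc2F)C1)N1CCN(c2ccccc2Cl)CC1` share one core and differ only in the ring carried on the saturated chain carbon bound to the amine nitrogen in a ring. In a functional assay on a cell-free system (Platelet, plasma, Homo sapiens), with stated times of 4 min and 5.5 min, tested at 0.1 uM (a lower number here means a stronger effect, a higher number a weaker effect of the compound at the concentration tested), compound 1 gives 90%, while compound 2 gives 50%, the lowest of the two numbers, with compound 1 its nearest neighbour. Going by the values given here, the only measured step, a number 40 percentage points lower from compound 1 to compound 2 (beyond the scatter), shows that altering this aromatic ring can move the read-out well beyond the scatter.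

Compound 3 `O=C(C1CCCN(Cc2ccc([N+](=O)[O-])cc2)C1)N1CCN(c2ccccc2Cl)CC1` carries 4-nitrophenyl in place of 2-fluorophenyl on a saturated chain carbon bound to an amine nitrogen in a ring. Among the compounds with values here, that single step is the only one bearing on this change, and it concerns the same ring, so another shift beyond the scatter is plausible, yet one step cannot fix its direction. A modest weakening is estimated, a number 20 percentage points higher from compound 2 to compound 3 (beyond the scatter). For compound 3 in this assay a value of 70% is expected, within 40% to 95%.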

Compound 3, a percentage reported as activity, at one concentration (the size of the read-out at that concentration, not a potency): 66%
Compound 3: the middle estimate sits 4 percentage points above what was measured, and the stated range covers the measured number.
By their numbers in this assay, from the lowest: compound 2; then compound 3; then compound 1.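

In this assay, adding a nitro group to the benzyl ring also lowers the number (a number 24 percentage points lower from compound 1 to compound 3 (beyond the scatter)), so a lower read-out at this position is no longer tied to fluoro alone. The two substituted rings are not interchangeable, however: placing 4-nitrophenyl where 2-fluorophenyl stood reverses part of that gain (a number 16 percentage points higher from compound 2 to compound 3 (beyond the scatter)), which leaves the 2-fluorobenzyl group with the lowest number of the three. Nothing measured on these compounds offers a reason for either step.

As their names show, 2-fluorophenyl and 4-nitrophenyl differ in both the group and its place on the ring, so these compounds cannot separate the two. Going by these compounds, whether a ring bearing a methoxy group, an amine or a carboxylic acid would lower the number further also stays open.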